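The compounds below may be only part of what the source reports. "The series", "measured", "known", "first", "only" and "open" are said of these compounds alone.

Measured so far:

Compound 1, `COc1cc(-c2cc(/C=C/C(=O)c3ccccc3)[nH]n2)cc(OC)c1OC`: 2300 nM
Compound 2, `COc1ccc(C(=O)/C=C/c2cc(-c3cc(OC)c(OC)c(OC)c3)n[nH]2)cc1`: 950 nM
Compound 3, `COc1ccc(-c2cc(/C=C/C(=O)c3cc(OC)c(OC)c(OC)c3)[nH]n2)cc1OC`: 2000 nM

All three numbers come from a functional assay on MDA-MB-231 cells (Homo sapiens) for inhibition, read by MTT assay, with a stated time of 48 h; a lower number here means a stronger inhibitor, a higher number a weaker inhibitor. Compound 2 gives 950 nM, the lowest of the three. Compound 3 gives 2000 nM, which sits within the usual scatter of compound 1 and beyond it relative to compound 2. Compounds 2 and 3 differ in more than one place; the difference between their two cores is not broken down here, so only their two values are compared.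

One structural change recurs. From compound 2 to compound 1 the change is hydrogen in place of methoxy on an aromatic carbon. The step it made was a 2.4-fold higher number from compound 2 to compound 1 (0.38 log units; beyond the scatter), a modest move to a weaker number.

Compound 4, `COc1ccc(-c2cc(/C=C/C(=O)c3cc(OC)c(OC)c(OC)c3)[nH]n2)cc1`, has not yet been measured in this assay. It differs from compound 3 by hydrogen in place of methoxy on an aromatic carbon. This is the same kind of change as from compound 2 to compound 1, though not the same: in compound 4 the position is ortho to a methoxy group and meta to a large group, whereas in compound 1 it is para to a large group.

For compound 4 the expected step is a 1.8-fold higher number from compound 3 to compound 4 (0.24 log units; within the scatter), placed beside the earlier one because the loss of a methoxy from compound 2 to compound 1 gave a 2.4-fold higher number from compound 2 to compound 1 (0.38 log units; beyond the scatter); the surroundings of the place differ, so the step is expected to be of similar or somewhat smaller size. The estimate for compound 4 is 3500 nM, expected to fall between 1500 nM and 8000 nM.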

Compound 4, half-maximal inhibitory concentration: 2400 nM
Compound 4: the middle estimate sits 1.5-fold (0.16 log units) above what was measured; low and high end bracket the measured number.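

In this assay, replacing methoxy with hydrogen on the 3,4-dimethoxyphenyl group, which leaves 4-methoxyphenyl, gives a 1.2-fold higher number from compound 3 to compound 4 (0.08 log units; within the scatter), so on this core the change cannot be told apart from repeat measurement. Set beside the earlier case, the two steps do not separate, and as far as these compounds can show, the change carries from one core to the other: the same change on two cores in this assay, a 2.4-fold higher number (0.38 log units; beyond the scatter) from compound 2 to compound 1 and a 1.2-fold higher number (0.08 log units; within the scatter) from compound 3 to compound 4, 2.0-fold (0.30 log units) apart, within the scatter of two such steps. Within the data shown here, this agreement rests on only two pairs, with one step beyond the scatter and one within it, and the change sits in different surroundings in each, so it establishes neither a constant step size nor a weaker number on every core.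

The compounds shown carry only methoxy or hydrogen at the changed places, leaving open how a fluorine or chlorine atom, a hydroxyl group or an amine would read there. Also open, on these data alone, is whether the step would hold with a longer chain in place of the one carrying the carbonyl, and whether it would appear in any read-out other than this assay.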